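The source may report more compounds than this note shows. Statements on the series, on what has been measured and on what is new or still open speak of the compounds shown alone.

In a functional assay on HL-60 cells (Homo sapiens) for antiproliferative activity, read by MTT assay, with a stated time of 72 h (a lower number here means a stronger inhibitor, a higher number a weaker inhibitor), compound 2 (`NC1=NC2(CCOCC2)N(OCCCOc2cccc(Cl)c2)C(N)=N1`) gives 520 nM and compound 1 (`NC1=NC2(CCOCC2)N(OCCCOc2ccc(Cl)cc2)C(N)=N1`) gives 330 nM and these two numbers lie within the usual scatter of each other. Compound 3 (`Cc1ccc(OCCCON2C(N)=NC(N)=NC23CCOCC3)cc1`) is still unmeasured and carries 4-methylphenyl in place of 3-chlorophenyl on an oxygen on a saturated carbon. Among the measured compounds shown here, the one measured step that bears on this is a 1.6-fold higher number from compound 1 to compound 2 (0.20 log units; within the scatter) and it only exchanges 4-chlorophenyl for 3-chlorophenyl. For the measured compounds named here, no measured step replaces a chlorophenyl with a methylphenyl, so no change beyond the scatter is expected in this assay here. The expected step is a 1.3-fold lower number from compound 2 to compound 3 (0.11 log units; within the scatter) and it remains an estimate. For compound 3 the estimated value is 400 nM with an expected range from 170 nM to 950 nM across repeat measurements.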

Compound 3, half-maximal inhibitory concentration: 2580 nM
Estimate against measurement, compound 3: 6.5-fold (0.81 log units) below; measured number above the stated range.
By their numbers in this assay, from the lowest: compounds 1 and 2 (each within the scatter of the next); then compound 3.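

In this assay the exchange of 3-chlorophenyl for 4-chlorophenyl stayed within the scatter, yet this position is not indifferent to every group: the step of methyl in place of chloro on an aromatic carbon gives a 7.8-fold higher number from compound 1 to compound 3 (0.89 log units; beyond the scatter) and is beyond the scatter. The exchange of 3-chlorophenyl for 4-methylphenyl, a 5.0-fold higher number from compound 2 to compound 3 (0.70 log units; beyond the scatter), is also beyond it. No evidence here explains why methyl and chloro differ. Going by these compounds, whether 3-methylphenyl would behave like 4-methylphenyl stays open, as does how a methoxy group or an amine on the same ring would compare.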